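Amide stereocentre inversion in a bis-sulfonamide piperidine series

A few compounds are considered here, and "the series" means these few. Any claim that something is new, unique, unknown or untested is made for them only; others in the source may bear on it.

Compound 2 `CCN(CC)S(=O)(=O)c1ccc(S(=O)(=O)N2CCC[C@@H](C(=O)N[C@H]3CCOC3)C2)cc1` gives 290 nM in a functional assay on MIA PaCa-2 cells (Homo sapiens) for inhibition, read by MTT assay, with a stated time of 3 days; on this read-out lower numbers stand for stronger inhibition and higher numbers for weaker inhibition. Going by the values given here, its only neighbour, compound 1 `CCN(CC)S(=O)(=O)c1ccc(S(=O)(=O)N2CCC[C@@H](C(=O)N3CCC(O)CC3)C2)cc1`, gives 230 nM in this assay; the two values lie within the scatter of each other, as the step of a 1.3-fold higher number from compound 1 to compound 2 (0.10 log units; within the scatter) shows. Compound 3 `CCN(CC)S(=O)(=O)c1ccc(S(=O)(=O)N2CCC[C@@H](C(=O)N[C@@H]3CCOC3)C2)cc1` is the next compound to be measured. Relative to compound 2: the two compounds have the same atoms and bonds and differ only in configuration as drawn: 1 of 2 stereo elements differ; a stereocentre at a saturated ring carbon is drawn S in compound 2 and R in compound 3. Among the compounds with values here, the single measured step, a 1.3-fold higher number from compound 1 to compound 2 (0.10 log units; within the scatter), concerns the exchange of the group on the carbonyl carbon and not the configuration of the oxolan-3-yl carbon, so it does not bear directly on the present change. Within the data shown here, no measured pair differs in configuration alone, and nothing in the data points to either configuration being preferred. Among the measured compounds shown here, the expected step of a 1.0-fold higher number from compound 2 to compound 3 (0.01 log units; within the scatter) is therefore taken as one that does not exceed the scatter, while the range is set wider than for the measured pair: an inverted stereocentre has no precedent among the measured compounds. Compound 3 is thus estimated at 300 nM, with a range of 120 nM to 750 nM.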

Compound 3, half-maximal inhibitory concentration: 100 nM
The estimate for compound 3 lay 3.0-fold (0.48 log units) above the measured number; measured number below the stated range.
By their numbers in this assay, from the lowest: compound 3; then compounds 1 and 2 (each within the scatter of the next).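

In this assay the configuration at the saturated ring carbon of the oxolan-3-yl group is not neutral: going from S to R gives a 2.9-fold lower number from compound 2 to compound 3 (0.46 log units; beyond the scatter), so this position responds to a change that leaves every atom and bond in place. The earlier exchange on the carbonyl carbon stayed within the scatter, whereas compound 3 now separates from the 4-hydroxypiperidin-1-yl amide as well, with a 2.3-fold lower number from compound 1 to compound 3 (0.36 log units; beyond the scatter), and the R-drawn oxolan-3-yl amide holds the lowest number of the three compounds. The gain can be assigned to this single stereocentre and to nothing else in the structure, because no other feature separates the pair: the fact that compounds 2 and 3 differ only in the configuration as drawn.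

On these data alone, whether the preference for R is a feature of the oxolan-3-yl group alone remains open, since a single pair of mirror-related amide groups cannot show if the same inversion would matter in a cyclopentylamine or a pyrrolidin-3-ylamine amide, where the ring oxygen is replaced by carbon or nitrogen. As far as these compounds go, the second stereo element is drawn alike in all three compounds, so its contribution to the numbers also remains unknown.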